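Varying the group on the carbonyl carbon

The source may hold more compounds than are shown below. What is called first, only, known or untested is meant among the compounds shown, and "the series" means these compounds.

Three measured compounds share one core and differ only in the group on the carbonyl carbon. Compound 1 `CC(=O)N1CCC(C(=O)N2C[C@@H](O[C@H](C)c3cc(C(F)(F)F)cc(C(F)(F)F)c3)[C@H](c3ccc(F)cc3)C2)CC1` gives 0.07 nM in an assay on CHO cells for displacement of a labelled ligand from Substance-P receptor (Homo sapiens) (a lower number here means a stronger inhibitor, a higher number a weaker inhibitor), and compound 2 `C[C@@H](O[C@@H]1CN(C(=O)[C@@H]2CCC(=O)N2C)C[C@H]1c1ccc(F)cc1)c1cc(C(F)(F)F)cc(C(F)(F)F)c1` gives 0.12 nM in this assay there. Compound 3 `Cc1cnc(C(=O)N2C[C@@H](O[C@H](C)c3cc(C(F)(F)F)cc(C(F)(F)F)c3)[C@H](c3ccc(F)cc3)C2)cn1` gives 0.12 nM in this assay and stands level with compound 2, the two together the highest numbers of the three, with compound 1 the furthest away. The steps of a 1.7-fold higher number from compound 1 to compound 3 (0.23 log units; within the scatter) and no change at the digits printed from compound 2 to compound 3 (within the scatter) stay within the scatter, as does a 1.7-fold higher number from compound 1 to compound 2 (0.23 log units; within the scatter) as well.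

Compound 4 `C[C@@H](O[C@@H]1CN(C(=O)N(C)C)C[C@H]1c1ccc(F)cc1)c1cc(C(F)(F)F)cc(C(F)(F)F)c1` continues the series through the change dimethylamino in place of 5-methylpyrazin-2-yl on a carbonyl carbon at the same place. All three measured steps bear on it, since each exchanges the group on this carbonyl carbon, and none moved this assay beyond the scatter. Within the data shown here, a similar outcome is expected here, with no basis in these compounds for a step beyond the scatter in either direction. Compound 4 is therefore estimated at 0.2 nM with a range from 0.06 nM to 0.7 nM in this assay overall. That estimate means a step of a 1.7-fold higher number from compound 3 to compound 4 (0.22 log units; within the scatter) and is expected to remain within the scatter.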

Compound 4, half-maximal inhibitory concentration: 0.38 nM
Compound 4: the middle estimate sits 1.9-fold (0.28 log units) below what was measured, within the range that was stated.
By their numbers in this assay, from the lowest: compounds 1, 2 and 3 (each within the scatter of the next); then compound 4.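

In this assay, among these compounds, this carbonyl carbon proves not to be indifferent to its group: dimethylamino brings a 3.2-fold higher number from compound 3 to compound 4 (0.50 log units; beyond the scatter) and a 3.2-fold higher number from compound 2 to compound 4 (0.50 log units; beyond the scatter) as well as a 5.4-fold higher number from compound 1 to compound 4 (0.73 log units; beyond the scatter) and these modest steps are the first to pass beyond the scatter. Dimethylamino is the only group here without a ring and the only one that puts a nitrogen directly on the carbonyl carbon, while the three ring-bearing groups remain within the scatter of one another. No measurement on these compounds gives a reason for the weaker binding.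

With a single compound of this kind, the loss of the ring and the change to a nitrogen on the carbonyl carbon cannot be told apart. A pyrrolidin-1-yl group or a diethylamino group at the same place would help separate the two.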